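The source may hold more compounds than are shown below. What is called first, only, known or untested is meant among the compounds shown, and "the series" means these compounds.

Measured so far:
Compound 1 `Oc1cccc(-c2cc(-c3ccco3)cc(-c3ccccc3O)n2)c1`: 0%
Compound 2 `Oc1ccccc1-c1cc(-c2cccnc2)cc(-c2ccccc2O)n1`: 0%

In an assay on isolated protein for inhibition of DNA topoisomerase 1 (Homo sapiens), with a stated time of 30 min, tested at 20 uM (on this read-out higher numbers stand for a stronger effect at the one concentration tested and lower numbers for a weaker effect), compound 2 gives 0%. This places compound 2 level with compound 1, which in this assay gives 0%, so the two are not separated beyond the usual scatter of such measurements, and neither shows any measurable effect at the concentration tested. For the measured compounds named here, no pair of measured compounds differing in a single place is available to show how a structural step moves this read-out.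

Compound 3 `Oc1cccc(-c2cc(-c3cccnc3)cc(-c3ccccc3O)n2)c1` has not yet been measured. It differs from compound 2 by a rearrangement of the same atoms: 3-hydroxyphenyl in place of 2-hydroxyphenyl on an aromatic carbon. Going by the values given here, both compounds measured so far sit at the floor of this read-out, so the step from compound 2 to compound 3 is expected to be none beyond the scatter, no change at the digits printed from compound 2 to compound 3 (within the scatter). Compound 3 is therefore estimated to give 0% in this assay, within a range from 0% to 10%.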

Compound 3, a percentage reported as inhibition, at one concentration (the size of the read-out at that concentration, not a potency): 0%
For compound 3 middle estimate and measured number coincide at the digits printed, and the stated range covers the measured number.
By their numbers in this assay, from the lowest: compounds 1, 2 and 3 (each within the scatter of the next).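

In this assay, putting 3-hydroxyphenyl in place of 2-hydroxyphenyl on the aromatic carbon next to the ring nitrogen gives no change at the digits printed from compound 2 to compound 3 (within the scatter), so this shift of the hydroxyl group does not lift the read-out off zero. For the compounds shown here, with the 3-hydroxyphenyl group in place, pyridin-3-yl in place of furan-2-yl on an aromatic carbon gives no change at the digits printed from compound 1 to compound 3 (within the scatter), which is the first single-place comparison for that group, and it too is flat. Nothing measured here explains why these compounds show no effect.

With all three compounds at zero, these steps cannot reveal whether either change would matter on a compound with measurable activity. From the compounds shown here alone, whether an amine, a carboxylic acid or a longer chain at either position would produce any inhibition remains open.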